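This account rests on a few compounds, and the source may have more. Where it says the series, first, only, none or still open, it means among the compounds named here.

Measured so far in an ADME assay on MT4 cells (Homo sapiens) for cytotoxicity, read by MTT assay; a higher number here means that more compound is tolerated, a lower number that less compound is tolerated:
- Compound 1 `Cc1c(Cc2c(F)cccc2F)nc(SCc2ccc([N+](=O)[O-])cc2)[nH]c1=O`: > 37000 nM (a limit)
- Compound 2 `Cc1c(Cc2c(F)cccc2F)nc(SC(C)C)[nH]c1=O`: > 77000 nM (a limit)
- Compound 3 `COc1ccc(CSc2nc(Cc3c(Cl)cccc3Cl)c(C)c(=O)[nH]2)cc1`: 32000 nM

For the measured compounds named here, compound 3 gives the only actual number of the series, 32000 nM. The other two values are limits, so compound 3 cannot be ranked against them. Compound 4 `COc1ccc(CCSc2nc(Cc3c(Cl)cccc3Cl)c(C)c(=O)[nH]2)cc1` differs from compound 3 in one place: 4-methoxybenzyl in place of 4-methoxyphenyl on a saturated chain carbon bound to a sulfur, with 4-methoxybenzyl in place of 4-methoxyphenyl on a saturated chain carbon bound to a sulfur. Going by the values given here, no measured pair differs in a single place, so nothing in this assay sizes this change directly, and no direction is favoured. The expected result is a step of a 1.1-fold lower number from compound 3 to compound 4 (0.03 log units; within the scatter), none beyond the scatter. For compound 4 the estimated value is 30000 nM, with an expected range of 14000 nM to 65000 nM.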

Compound 4, half-maximal cytotoxic concentration: > 57000 nM
Compound 4 ended at the assay's limit; the forecaster's own chance of this, stated with the estimate: 30%; at least 1.9-fold (0.27 log units) between middle value and limit.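

In this assay, for the compounds shown here, this is the first comparison that differs in a single place: 4-methoxybenzyl in place of 4-methoxyphenyl on a saturated chain carbon bound to a sulfur gives an at least 1.7-fold higher number from compound 3 to compound 4 (0.25 log units; that floor lies within the scatter). That floor does not separate the two compounds, though this change brings no lower number. Compound 4 carries a limit, not a number: the limit of > 57000 nM in this assay, at which 1 of the 4 values shown sits.

From the compounds shown here alone, the true size of the step remains open. So does the outcome for a longer chain at this place, or for an amine in place of the methoxy group.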